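Methoxy in Place of Fluoro: Expecting a Value for Compound 3

The source may hold more compounds than are shown below. What is called first, only, known or untested is meant among the compounds shown, and "the series" means these compounds.

Measured compounds:
Compound 1 `O=C(O)C[C@H](O)C[C@H](O)CCn1c(-c2ccc(F)cc2)nc(C(=O)NCc2ccccc2F)c1C1CC1`: in a functional assay on cells (Hepatocyte, Rattus norvegicus) for inhibition, read by scintillation counting, with a stated time of 4 h (on this read-out higher numbers stand for weaker inhibition and lower numbers for stronger inhibition), compound 1 gives "not determined" (no result reported).
Compound 2 `O=C(O)C[C@H](O)C[C@H](O)CCn1c(-c2ccc(F)cc2)nc(C(=O)NCc2cccc(F)c2)c1C1CC1`: in this assay compound 2 gives 0.1 nM.

Compound 1 stands without a number in this assay: no result was reported for it, so it cannot be placed on the scale. Among the compounds with values here, compound 2, the only compound with a result, gives a value at the low end of the scale, which on this read-out stands for strong inhibition.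

Compound 3 `COc1ccccc1CNC(=O)c1nc(-c2ccc(F)cc2)n(CC[C@@H](O)C[C@@H](O)CC(=O)O)c1C1CC1` is built from compound 1 by one change, (methoxy in place of fluoro on an aromatic carbon). Within the data shown here, no step between measured compounds exists to calibrate this change, and with compound 1 itself unmeasured, the step is expected to be small, with no direction beyond the usual scatter that can be called.

Compound 3 is therefore expected to give 0.3 nM in this assay, within an estimated range from 0.05 nM to 3 nM.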

Compound 3, half-maximal inhibitory concentration: 0.1 nM
Compound 3: the middle estimate sits 3.0-fold (0.48 log units) above what was measured; low and high end bracket the measured number.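

In this assay there is no change at the digits printed from compound 2 to compound 3 (within the scatter), so the earlier single number for a fluoro-bearing benzyl amide now has a partner with a different group on this ring. The result shows that this part of the molecule can carry a methoxy on an aromatic carbon ortho to a large group, as in the 2-methoxybenzyl amide, and still read at the low end of the scale, where inhibition is strong. Nothing given here bears on why the two compounds read alike.

The step from compound 1 to compound 3 cannot be read, as compound 1 has no number, so fluoro and methoxy at this same place remain uncompared. Also open, going by these compounds, is how an amine, a hydroxyl or a longer ether chain such as ethoxy would read on this aromatic carbon.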